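The compounds below may be only part of what the source reports. "The series", "measured", "known", "first", "only" and "open" are said of these compounds alone.

Compound 1 `O=C(CSc1nnnn1-c1ccccc1)N/N=c1/scc(-c2ccc(Br)cc2)n1-c1ccccc1` and compound 2 `Cc1ccc(-c2cs/c(=N/NC(=O)CSc3nnnn3-c3ccccc3)n2-c2ccccc2)cc1` share one core. In a functional assay on C6 cells (Rattus norvegicus) for cytotoxicity, read by MTT assay, with a stated time of 24 h (on this read-out lower numbers stand for stronger inhibition and higher numbers for weaker inhibition), compound 1 gives 21 ug/mL and compound 2 gives 14.7 ug/mL. The change between them is methyl in place of bromo on an aromatic carbon and it made a step of a 1.4-fold lower number from compound 1 to compound 2 (0.15 log units; within the scatter). Compound 3 `Cc1nnc(SCC(=O)N/N=c2/scc(-c3ccc(Br)cc3)n2-c2ccccc2)s1` differs from compound 1 in its core by 5-methyl-1,3,4-thiadiazol-2-yl in place of 1-phenyl-1H-tetrazol-5-yl on a sulfur. In this assay compound 3 gives "not determined" (no result reported), so no single number stands for compound 3. Compound 4 `Cc1ccc(-c2cs/c(=N/NC(=O)CSc3nnc(C)s3)n2-c2ccccc2)cc1`, not yet measured, differs from compound 3 by methyl in place of bromo on an aromatic carbon; the place is the same in both pairs, so this is the same change. Within the data shown here, from compound 3 to compound 4 a step of about the size seen from compound 1 to compound 2 is expected in this assay, resting on a 1.4-fold lower number from compound 1 to compound 2 (0.15 log units; within the scatter) alone, with compound 2 as the only numeric anchor since compound 3 has none. Compound 4 is expected to give 15 ug/mL in this assay, between 7 ug/mL and 35 ug/mL.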

Compound 4, half-maximal inhibitory concentration: 25.3 ug/mL
Estimate against measurement, compound 4: 1.7-fold (0.23 log units) below; low and high end bracket the measured number.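

Placing 5-methyl-1,3,4-thiadiazol-2-yl in place of 1-phenyl-1H-tetrazol-5-yl on the sulfur, with the 4-methylphenyl kept, gives a 1.7-fold higher number from compound 2 to compound 4 (0.24 log units; within the scatter) in this assay and so does not separate the two compounds on this read-out. Going by these compounds, compound 3 has no number, so the step to compound 4 cannot be read, and whether the change from 4-bromophenyl to 4-methylphenyl carries from one core to the other remains untested. No measured evidence bears on the cause of these values.

The compounds shown leave open how this assay would respond to an amine or a carboxylic acid in place of the bromo or methyl on the aromatic carbon. They also leave open whether the same change gives a comparable step on any other group on the sulfur.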